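This account rests on a few compounds, and the source may have more. Where it says the series, first, only, none or still open, it means among the compounds named here.

In a functional assay on A549 cells (Homo sapiens) for antiproliferative activity, read by MTT assay, with a stated time of 48 h (a lower number here means a stronger inhibitor, a higher number a weaker inhibitor), compound 2 (`C=C(c1ccc2c(c1)C=CC(C)(C)O2)c1ccc(OC)cc1NC(=O)CO`) gives 40 nM and compound 3 (`C=C(c1cc(OC)c(OC)c(OC)c1)c1ccc(OC)cc1NC(=O)CO`) gives 20 nM, two values within the usual scatter of each other. Compound 1 (`CCNCC(=O)Nc1cc(OC)ccc1C(=O)c1ccc(OC)c2c1C=CC(C)(C)O2`) gives 2310 nM, a number far higher than either, so compound 2 sits with the stronger pair. Compound 4 (`C=C(c1ccc2c(c1)C=CC(C)(C)O2)c1ccc(OC)cc1NC(=O)CNC`) has methylamino in place of hydroxy on a saturated chain carbon bound to a carbonyl carbon. Among the measured compounds shown here, no measured pair shows this change alone. Compound 1 also carries a nitrogen on that chain and gives 2310 nM, but it differs elsewhere too, so it is only a loose guide. A moderate weakening beyond the scatter is expected, with an estimated 3.8-fold higher number from compound 2 to compound 4 (0.57 log units; beyond the scatter). For compound 4, the estimated value is 150 nM, with an expected range of 40 nM to 500 nM.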

Compound 4, half-maximal inhibitory concentration: 200 nM
The estimate for compound 4 lay 1.3-fold (0.12 log units) below the measured number; measured number inside the range.
By their numbers in this assay, from the lowest: compounds 3 and 2 (each within the scatter of the next); then compound 4; then compound 1.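

In this assay, methylamino in place of hydroxy on a saturated chain carbon bound to a carbonyl carbon gives a 5.0-fold higher number from compound 2 to compound 4 (0.70 log units; beyond the scatter). Among the compounds shown here, this is the first clean reading of this position, since compound 1 differs from compound 2 in more than one place. The number moves beyond the scatter even though the count of hydrogen-bond donors and acceptors stays the same, and nothing at hand explains the step.

Open, from the compounds shown here alone, is whether a plain amino group or a methoxy group at this place would track hydroxy or methylamino. Also open, going by these compounds, is whether the same change would cost as much on the core of compound 3.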